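The source may hold more compounds than are shown below. What is called first, only, known or untested is meant among the compounds shown, and "the series" means these compounds.

Of the compounds shown here, two have so far been measured in an assay on frontal cortex for displacement of a labelled ligand from corticotropin-releasing factor receptor 1 (Rattus norvegicus); on this read-out higher numbers stand for weaker inhibition and lower numbers for stronger inhibition. Compound 1, with the structure `COc1cc(C)c(Nc2nc(Cl)cn([C@H](C)C3CC3)c2=O)c(C)n1`, gives 12 nM. Compound 2, with the structure `CCOc1nc(C)c(Nc2nc(Cl)cn([C@H](C)C3CC3)c2=O)cc1C`, gives 2.7 nM. Of these two numbers compound 2 holds the lower one, and its gap to compound 1 lies beyond the usual scatter of repeated measurements, so compound 2 is the stronger inhibitor of the pair. The two compounds differ at more than one place, so no single structural change can be read from them.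

Compound 3, with the structure `Cc1cc(Nc2nc(Cl)cn([C@H](C)C3CC3)c2=O)c(C)nc1N(C)C`, is still to be measured in this assay. It differs from compound 2 in one place: dimethylamino in place of ethoxy on an aromatic carbon. Among the measured compounds shown here, no measured pair shows this exchange, so no step of this kind is known here. With only compound 2 as a point of comparison, the expectation is a step that stays within or close to the scatter, with no firm direction. Compound 3 is therefore expected to give about 4 nM in this assay, between 1.5 nM and 12 nM. That estimate corresponds to an expected step of a 1.5-fold higher number from compound 2 to compound 3 (0.17 log units; within the scatter).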

Compound 3, half-maximal inhibitory concentration: 0.68 nM
The estimate for compound 3 lay 5.9-fold (0.77 log units) above the measured number; measured number outside the range, below it.
By their numbers in this assay, from the lowest: compound 3; then compound 2; then compound 1.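

Among the compounds shown here, at this position, on an aromatic carbon next to the ring nitrogen, the step to dimethylamino in place of ethoxy is a 4.0-fold lower number from compound 2 to compound 3 (0.60 log units; beyond the scatter) in this assay, the first single-place comparison in this set and one that shows this position can change the read-out beyond the usual scatter. The two groups match in their counts of heavy atoms, hydrogen-bond donors and hydrogen-bond acceptors, and neither has a ring or a net charge, so these counts do not separate them; the exchange replaces the oxygen of ethoxy with the nitrogen of dimethylamino and changes the carbons attached to it. Nothing available here accounts for the lower number of compound 3.

Going by these compounds, with a single pair, it remains open whether the same exchange would lower the number on a different core arrangement, such as that of compound 1. On these data alone, it is also open how other groups at this position would compare, for example a diethylamino group, a pyrrolidine ring or a plain amine.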